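The compounds below may be only part of what the source reports. "The series", "measured", "known", "first", "only" and "open" are said of these compounds alone.

Measured in a functional assay on MDA-MB-231 cells (Homo sapiens) for antiproliferative activity, read by MTT assay, with a stated time of 24 h; on this read-out higher numbers stand for weaker inhibition and lower numbers for stronger inhibition:

compound 1 `COc1cc(/C=C/C(=O)c2cc(-c3cc(OC)c(OC)c(OC)c3)n3nc(-c4ccccc4)cc3n2)cc(OC)c1OC`: 18400 nM
compound 2 `COc1cc(-c2cc(/C=C/C(=O)c3ccc(C)c(C)c3)nc3cc(-c4ccccc4)nn23)cc(OC)c1OC`: 13500 nM
compound 3 `COc1ccc(/C=C/C(=O)c2cc(-c3cc(OC)c(OC)c(OC)c3)n3nc(-c4ccccc4)cc3n2)cc1`: 16500 nM

Compound 3 stands second highest of the three numbers, but both gaps around it are within the scatter: a 1.1-fold lower number from compound 1 to compound 3 (0.05 log units; within the scatter) and a 1.2-fold higher number from compound 2 to compound 3 (0.09 log units; within the scatter). On the numbers shown the three compounds cannot be ordered.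

Compound 4 `COc1cc(-c2cc(C(=O)/C=C/c3ccccc3)nc3cc(-c4ccccc4)nn23)cc(OC)c1OC` is not yet measured. Against compound 3 the change is hydrogen in place of methoxy on an aromatic carbon.

Of the measured steps, the one that bears most closely is a 1.1-fold lower number from compound 1 to compound 3 (0.05 log units; within the scatter), where the substitution on the same aryl ring was changed from 3,4,5-trimethoxyphenyl to 4-methoxyphenyl with nothing beyond the scatter. The other step, a 1.2-fold higher number from compound 2 to compound 3 (0.09 log units; within the scatter), rearranged the whole chain and likewise stayed within the scatter. Within the data shown here, no measured pair isolates the single methoxy that leaves here. Compound 4 is therefore expected to sit close to compound 3 in this assay, the expected step being a 1.0-fold higher number from compound 3 to compound 4 (0.01 log units; within the scatter), i.e. none beyond the scatter. For compound 4 the estimate in this assay is 17000 nM, expected to fall between 8000 nM and 35000 nM.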

Compound 4, half-maximal inhibitory concentration: 19200 nM
Estimate against measurement, compound 4: 1.1-fold (0.05 log units) below, and the stated range covers the measured number.
By their numbers in this assay, from the lowest: compounds 2, 3, 1 and 4 (each within the scatter of the next).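

Among these compounds, with the methoxy para to a large group removed, 4-methoxyphenyl to phenyl gives a 1.2-fold higher number from compound 3 to compound 4 (0.07 log units; within the scatter) in this assay, the first direct reading of this single position. Going from 3,4,5-trimethoxyphenyl to phenyl on the same ring gives a 1.0-fold higher number from compound 1 to compound 4 (0.02 log units; within the scatter) and so reaches a ring with no methoxy at all, while the exchange of the whole chain gives a 1.4-fold higher number from compound 2 to compound 4 (0.15 log units; within the scatter). No measurement at hand bears on the reason for these results.

Going by these compounds, every step among the four compounds lies within the scatter, so it stays open whether any substituent on this ring can shift the number beyond it in this assay at all. An amine or a carboxylic acid at this same place on the phenyl of compound 4 would put that question to a group of a different kind.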